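This account rests on a few compounds, and the source may have more. Where it says the series, first, only, none or still open, it means among the compounds named here.

Three related compounds have been measured in an assay on HEK293 cells for displacement of a labelled ligand from NPC1-like intracellular cholesterol transporter 1 (Homo sapiens); a lower number here means a stronger inhibitor, a higher number a weaker inhibitor. Compound 1 `CC(C)(C)OC(=O)NCC1CCCN(C(=O)CN2CN(c3ccccc3)C3(CCN(C(=O)c4ccc(C5CCCCC5)cc4)CC3)C2=O)C1` gives 3800 nM in this assay. Compound 2 `CS(=O)(=O)NCCCNC(=O)CN1CN(c2ccccc2)C2(CCN(C(=O)c3ccc(C4CCCCC4)cc3)CC2)C1=O` gives 3800 nM, the same number as compound 1 at the digits shown. Compound 3 `CCc1nn(CC)c(C2CCN(C(=O)CN3CN(c4ccccc4)C4(CCN(C(=O)c5ccc(C(C)(C)C)cc5)CC4)C3=O)CC2)c1C` gives 2500 nM, a number that differs from that of compound 2 by less than the usual scatter of repeated measurements. Compound 2 thus stands level with compound 1, and all three numbers lie within the scatter of one another, so no ranking among them can be read from these results.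

Compound 4 `CC1(C)CC(OC(=O)CN2CN(c3ccccc3)C3(CCN(C(=O)c4ccc(C5CCCCC5)cc4)CC3)C2=O)CC(C)(C)N1` has not yet been measured. It shares the core of compound 2 and differs from it in one place: (2,2,6,6-tetramethylpiperidin-4-yl)oxy in place of (3-(methanesulfonamido)propyl)amino on a carbonyl carbon. Among the compounds with values here, no measured pair in this set differs in this way, so there is no measured step to lean on. The three measured numbers lie close together despite differences elsewhere in the molecules, which gives no reason to expect a large move. Compound 4 is therefore expected to give about 3500 nM in this assay, with a range from 1200 nM to 10000 nM. This estimate means a step of a 1.1-fold lower number from compound 2 to compound 4 (0.04 log units; within the scatter) that is expected to stay within the scatter, in no particular direction.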

Compound 4, half-maximal inhibitory concentration: 600 nM
Compound 4: the middle estimate sits 5.8-fold (0.77 log units) above what was measured, and the stated range ends above it.
By their numbers in this assay, from the lowest: compound 4; then compounds 3, 1 and 2 (each within the scatter of the next).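

In this assay, the group on this carbonyl carbon, whose other neighbour is a saturated chain carbon, can clearly change the number: (2,2,6,6-tetramethylpiperidin-4-yl)oxy in place of (3-(methanesulfonamido)propyl)amino gives a 6.3-fold lower number from compound 2 to compound 4 (0.80 log units; beyond the scatter). Within the data shown here, the three earlier numbers all lay within the scatter of one another and no measured step linked them, so this is the first sign in the set that a single change can matter. The change is a composite one, since a chain without a ring leaves, a six-membered non-aromatic ring enters, and the sulfur-containing part goes, and nothing available here explains the step or ties it to any one of these parts.

The compounds shown leave open whether the ring or the oxygen link carries the step: a (2,2,6,6-tetramethylpiperidin-4-yl)amino group would keep the ring and replace the oxygen with an amine nitrogen. A piperidin-4-yloxy group, without the methyl groups, would likewise ask whether those methyls are needed for the lower number.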